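Phenyl in place of methyl, tried at a second position

A few compounds are considered here, and "the series" means these few. Any claim that something is new, unique, unknown or untested is made for them only; others in the source may bear on it.

Compound 1 `Cc1ccccc1-c1cc(C(C)(C)C)cc(C(C)C)c1CO` carries a 2-methylphenyl group on the shared core. In a functional assay on RKE cells for antagonist activity at Vasoactive intestinal polypeptide receptor 1 (Rattus norvegicus), read by HTRF and cAMP accumulation, with stated times of 10 min and 30 min (on this read-out lower numbers stand for stronger inhibition and higher numbers for weaker inhibition), compound 1 reports only a limit, > 50000 nM, with the limit of > 50000 nM in this assay, at which 1 of the 3 values shown sits, marking that limit. Compound 2 `CC(C)c1cc(C(C)(C)C)cc(-c2ccccc2-c2ccccc2)c1CO` differs by phenyl in place of methyl on an aromatic carbon; in this assay compound 2 gives 3200 nM, and the step is an at least 15-fold lower number from compound 1 to compound 2 (1.19 log units; beyond the scatter). Compound 3 `Cc1cccc(-c2cc(C(C)(C)C)cc(C(C)C)c2CO)c1` differs from compound 1 by 3-methylphenyl in place of 2-methylphenyl on an aromatic carbon; in this assay compound 3 gives 240 nM, and the step is an at least 200-fold lower number from compound 1 to compound 3 (2.31 log units; beyond the scatter). Compound 4 `CC(C)c1cc(C(C)(C)C)cc(-c2cccc(-c3ccccc3)c2)c1CO` is not yet measured; it differs from compound 3 by phenyl in place of methyl on an aromatic carbon. This is the same kind of change as from compound 1 to compound 2, though the place differs: there the phenyl enters ortho to a large group, here meta to a large group. Because the earlier step of an at least 15-fold lower number from compound 1 to compound 2 (1.19 log units; beyond the scatter) started from a limit, its true size is uncertain, so a smaller step is expected here, a 3.4-fold lower number from compound 3 to compound 4 (0.54 log units; beyond the scatter). Compound 4 is therefore estimated at 70 nM, with a range from 10 nM to 500 nM.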

Compound 4, half-maximal inhibitory concentration: 210 nM
The estimate for compound 4 lay 3.0-fold (0.48 log units) below the measured number; the range from low to high includes it.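

In this assay, the same change, phenyl in place of methyl on an aromatic carbon, here meta to a large group, gives a 1.1-fold lower number from compound 3 to compound 4 (0.06 log units; within the scatter). The change therefore does not carry over from one core to the other with the same size: the same change on two cores in this assay, an at least 15-fold lower number (1.19 log units; beyond the scatter) from compound 1 to compound 2 and a 1.1-fold lower number (0.06 log units; within the scatter) from compound 3 to compound 4, at least 13-fold (1.13 log units) apart, beyond the scatter of two such steps Compound 1 reports only a limit, so the earlier step has no exact size, and these two pairs do not say whether the core or the place of the change sets the gap between the steps: the limit of > 50000 nM in this assay, at which 1 of the 4 values shown sits.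

The compounds shown carry only hydrocarbon groups at the changed place, so it remains open how an amine, a carboxylic acid or a longer chain there would read in this assay. Going by these compounds, it also remains open whether phenyl in place of methyl at any further position would follow the larger step, the smaller one or neither.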